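Replacing a benzylurea by a benzothiazole on the anilino nitrogen

The compounds below may be only part of what the source reports. "The series", "measured", "known", "first", "only" and "open" are said of these compounds alone.

Measured so far:
compound 1, `COc1ccc(Nc2nc(C)c(-c3ccc(C)c(C)c3)c(C(OC(C)(C)C)C(=O)O)c2C)cc1`, 28000 nM
compound 2, `Cc1ccc(-c2c(C)nc(NC(=O)NCc3ccccc3)c(C)c2C(OC(C)(C)C)C(=O)O)cc1C`, 17000 nM

In an ADME assay on MT4 cells (Homo sapiens) for cytotoxicity, read by MTT assay (on this read-out lower numbers stand for higher toxicity in this test and higher numbers for lower toxicity in this test), compound 2 gives 17000 nM, and the change a 1.6-fold lower number from compound 1 to compound 2 (0.22 log units; within the scatter) leaves the two numbers within the scatter of each other. Compound 3 is `Cc1ccc(-c2c(C)nc(Nc3nc4ccccc4s3)c(C)c2C(OC(C)(C)C)C(=O)O)cc1C`; it differs from compound 2 by 1,3-benzothiazol-2-yl in place of benzylcarbamoyl on a nitrogen on an aromatic ring. Among the compounds with values here, the only step measured on this nitrogen, a 1.6-fold lower number from compound 1 to compound 2 (0.22 log units; within the scatter), stayed within the scatter, so no step beyond the scatter is expected here either. Compound 3 is therefore estimated at 20000 nM, in the range 6000 nM to 60000 nM, an expected step of a 1.2-fold higher number from compound 2 to compound 3 (0.07 log units; within the scatter) in this assay.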

Compound 3, half-maximal cytotoxic concentration: 6600 nM
Compound 3: middle estimate off by 3.0-fold (0.48 log units), on the high side; the measured number falls inside the stated range.
By their numbers in this assay, from the lowest: compound 3; then compounds 2 and 1 (each within the scatter of the next).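

In this assay, this nitrogen now gives its first steps beyond the scatter: putting 1,3-benzothiazol-2-yl here gives a 2.6-fold lower number from compound 2 to compound 3 (0.41 log units; beyond the scatter) and a 4.2-fold lower number from compound 1 to compound 3 (0.63 log units; beyond the scatter), so the group on this nitrogen can shift toxicity in this test, if only modestly. Benzylcarbamoyl and 4-methoxyphenyl stayed within the scatter of each other, so the benzothiazole alone stands apart. No measurement available here explains this difference.

As far as these compounds go, it remains open whether a thiazole without the fused benzene ring, or a pyridine, would lower the number as well.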